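Series notes: core substituent exchange and acid dissociation

This account rests on a few compounds, and the source may have more. Where it says the series, first, only, none or still open, it means among the compounds named here.

Three members of the series have been measured so far. Compound 1 `COc1cccc(Oc2ccc3c(NCCCNCc4cc(F)ccc4OC)ccnc3c2)c1` gives 9.28 in a physicochemical assay for acid dissociation. Compound 2 `COc1cccc(Oc2ccc3c(NCCCNCc4cccc(OC)c4O)ccnc3c2)c1` gives 9.28 and compound 3 `COc1ccc(Oc2ccc3c(NCCCNCc4ccco4)ccnc3c2)cc1` gives 9.28; compound 1 therefore stands level with both at the digits reported, its nearest neighbour being compound 2 and its furthest compound 3, with no change beyond the scatter in either case. Within the data shown here, the one step with a single point of difference, no change at the digits printed from compound 1 to compound 2 (within the scatter), exchanges the aryl group on the saturated chain carbon bound to the amine nitrogen and leaves the acid dissociation constant where it was.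

Compound 4 `CCC(CC)c1ccc2c(NCCCNCc3cc(F)ccc3OC)ccnc2c1` is the next candidate for this assay. Its change from compound 1 is pentan-3-yl in place of 3-methoxyphenoxy on an aromatic carbon; the leaving group carries one six-membered aromatic ring of carbon only and two hydrogen-bond acceptors, the entering pentan-3-yl carries no ring and no acceptors, and the site is an aromatic carbon of the fused two-ring core, meta and para to a fused ring. Among the measured compounds shown here, no measured step touches this site, so the bearing of the series on it is indirect: every exchange so far, on whichever part of the molecule, has left the value unchanged, and nothing suggests a different outcome here. The expected step of a number 0.02 log units higher from compound 1 to compound 4 (within the scatter) is therefore none beyond the scatter. Compound 4 is estimated at 9.3, within 8.9 to 9.7.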

Compound 4, acid dissociation constant: 9.47
Compound 4: the middle estimate sits 0.17 log units below what was measured; the measured number falls inside the stated range.
By their numbers in this assay, from the lowest: compounds 1, 2, 3 and 4 (each within the scatter of the next).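

Working notes on the new step: a measured step now reaches the aromatic carbon of the shared core for the first time, meta to a fused ring and para to a fused ring. In this assay the exchange of 3-methoxyphenoxy for pentan-3-yl gives a number 0.19 log units higher from compound 1 to compound 4 (within the scatter), so the read-out at this site stays within the scatter even though the entering group differs widely from the leaving one. A group with a six-membered aromatic ring of carbon only and hydrogen-bond acceptors gives way to one with no ring and no hydrogen-bond acceptors, whereas the earlier step only exchanged one aryl group for another on the saturated chain carbon, and nothing available explains why the number sits where it does.

As far as these compounds go, this site rests on a single pair, so it remains open whether an amine or a carboxylic acid on the same aromatic carbon would also stay within the scatter of compound 1. Also open, from the compounds shown here alone, is whether pentan-3-yl would give a similar step alongside the side chains of compound 2 and compound 3.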